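Hydrazone series: paw edema inhibition at one dose

A few compounds are considered here, and "the series" means these few. Any claim that something is new, unique, unknown or untested is made for them only; others in the source may bear on it.

Measured compounds:
compound 1 `O=C(N/N=C/c1cccc(F)c1)c1cccnc1Nc1cccc(C(F)(F)F)c1` — 51.5%
compound 2 `O=C(N/N=C/c1ccc(Cl)cc1)c1cccnc1Nc1cccc(C(F)(F)F)c1` — 67.2%
compound 3 `O=C(N/N=C/c1ccc(O)cc1)c1cccnc1Nc1cccc(C(F)(F)F)c1` — 70.5%

All three numbers come from a functional assay on the whole organism (strain Wistar) for inhibition, with Rattus norvegicus as the target, read by paw edema, with a stated time of 1 h, at a dose of 10 mg/kg by the intraperitoneal route; on this read-out lower numbers stand for less inhibition and higher numbers for more inhibition at the one dose given (going by the name of the read-out). Compound 1 stands lowest of the three. The nearest of the others is compound 2, with a number 15.7 percentage points higher from compound 1 to compound 2 (beyond the scatter); the furthest is compound 3, with a number 19 percentage points higher from compound 1 to compound 3 (beyond the scatter). Between compounds 2 and 3 the gap is a number 3.3 percentage points higher from compound 2 to compound 3 (within the scatter), so those two cannot be ordered.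

Compound 4 `O=C(N/N=C/c1ccc(O)c(O)c1)c1cccnc1Nc1cccc(C(F)(F)F)c1` is not yet measured in this assay. Against compound 1 the change is 3,4-dihydroxyphenyl in place of 3-fluorophenyl on a carbon with a double bond to nitrogen. Among the measured compounds shown here, the step that bears most directly on it is the one to compound 3, which already carries a hydroxy on the ring, a number 19 percentage points higher from compound 1 to compound 3 (beyond the scatter); the step to compound 2, a number 15.7 percentage points higher from compound 1 to compound 2 (beyond the scatter), points the same way. Nothing measured here tells whether the second hydroxy adds to or takes from that effect. The step from compound 1 is therefore expected to be a number 20.5 percentage points higher from compound 1 to compound 4 (beyond the scatter), upward and modest. Compound 4 is estimated at 72%, expected between 60% and 84%.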

Compound 4, a percentage reported as inhibition, in the whole organism at one dose (the size of the read-out at that dose, not a potency): 50.8%
The estimate for compound 4 lay 21.2 percentage points above the measured number, and the stated range ends above it.
By their numbers in this assay, from the lowest: compounds 4 and 1 (each within the scatter of the next); then compounds 2 and 3 (each within the scatter of the next).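

In this assay a second hydroxy on the ring of compound 3 does not build on the first, and the change gives a number 19.7 percentage points lower from compound 3 to compound 4 (beyond the scatter) instead. The 3,4-dihydroxyphenyl group also gives a number 16.4 percentage points lower from compound 2 to compound 4 (beyond the scatter) and, against the 3-fluorophenyl group, a number 0.7 percentage points lower from compound 1 to compound 4 (within the scatter) so on a carbon with a double bond to nitrogen, a hydroxy on the ring does not by itself secure the higher numbers seen with compound 3. No measurement offered here bears on the reason for this loss.

Still open, on these data alone, is whether the loss follows from the added hydroxy alone or from the two hydroxy groups together. A 3-hydroxyphenyl, 4-methoxyphenyl or 4-aminophenyl group at the same place would help to separate these readings.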